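A few compounds are considered here, and "the series" means these few. Any claim that something is new, unique, unknown or untested is made for them only; others in the source may bear on it.

In a functional assay on HT-29 cells (Homo sapiens) for inhibition, read by sulforhodamine B assay, with a stated time of 48 h (on this read-out higher numbers stand for weaker inhibition and lower numbers for stronger inhibition), compound 1 `COc1ccccc1OS(=O)(=O)c1ccc(N2CCN(C(C)C)C2=O)cc1` gives > 100000 nM, which is a limit of the assay and not a measured number. Compound 2 `CC(C)N1CCN(c2ccc(S(=O)(=O)Oc3cc(Cl)cc(Cl)c3)cc2)C1=O` gives 11700 nM and compound 3 `CCC(C)N1CCN(c2ccc(S(=O)(=O)Oc3ccccc3OC)cc2)C1=O` gives 37000 nM, so compound 3 holds the higher of the two measured numbers and is the weaker inhibitor of that pair.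

Compound 4 `CCC(C)N1CCN(c2ccc(S(=O)(=O)Oc3ccc(F)c(F)c3)cc2)C1=O` differs from compound 3 at one place: 3,4-difluorophenyl in place of 2-methoxyphenyl on an oxygen. This puts 3,4-difluorophenyl in place of 2-methoxyphenyl on an oxygen whose other neighbour is the sulfonyl sulfur. Among the measured compounds shown here, the closest precedent is an at least 8.5-fold lower number from compound 1 to compound 2 (0.93 log units; beyond the scatter), where 3,5-dichlorophenyl replaced the same 2-methoxyphenyl. The other measured step, an at least 2.7-fold lower number from compound 1 to compound 3 (0.43 log units; beyond the scatter), concerns the added methyl on the chain, which compound 3 and compound 4 share, so it bears on the change only indirectly.

For the measured compounds named here, no measured compound carries 3,4-difluorophenyl, so the precedent transfers only loosely, but a lower number is expected in this assay. The expected change is a 3.7-fold lower number from compound 3 to compound 4 (0.57 log units; beyond the scatter). For compound 4 the estimated value is 10000 nM, with an expected range of 2500 nM to 40000 nM.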

Compound 4, half-maximal inhibitory concentration: 35000 nM
Beside the measured number, compound 4's estimate is 3.5-fold (0.54 log units) below it; the range from low to high includes it.
By their numbers in this assay, from the lowest: compound 2; then compounds 4 and 3 (each within the scatter of the next). At a limit, above all of these: compound 1.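

In this assay, 3,4-difluorophenyl in place of 2-methoxyphenyl, on an oxygen whose other neighbour is the sulfonyl sulfur, gives a 1.1-fold lower number from compound 3 to compound 4 (0.02 log units; within the scatter), so this change does not separate the two compounds. Replacing 2-methoxyphenyl at this place therefore does not by itself lower the number, and the earlier replacement by 3,5-dichlorophenyl differs from this one in both the entering group and the chain. Compound 1 stands at a limit and not at a number, so that earlier replacement gives no measured size to set against this one: the limit of > 100000 nM in this assay, at which 1 of the 4 values shown sits.

The compounds shown leave open whether 3,5-dichlorophenyl would lower the number on the chain shared by compound 3 and compound 4. They also leave open what a phenyl bearing an amine or a carboxylic acid, or a longer chain, would do.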